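The compounds below may be only part of what the source reports. "The series", "measured", "known", "first", "only" and "open" are said of these compounds alone.

Of the compounds shown here, two built on the shared core have numbers so far in a functional assay on SK-BR-3 cells (Homo sapiens) for cytotoxicity, read by MTT assay, with a stated time of 72 h (a higher number here means a weaker inhibitor, a lower number a stronger inhibitor), and both sit high on the scale. There compound 1 `N[C@H]1CC[C@H](Nc2c(C(=O)NCc3ccco3)nc(Br)c3cccnc23)CC1` gives 10000 nM and compound 2 `Nc1ccc(Nc2c(C(=O)NCc3ccc(F)cc3)nc(Br)c3cccnc23)cc1` gives 4000 nM as the lower of the two numbers, a gap beyond the usual scatter. Compound 3 `COC(=O)CNc1c(C(=O)NCc2ccc(F)cc2)nc(Br)c2cccnc12` has no number yet and differs from compound 2 by (methoxycarbonyl)methyl in place of 4-aminophenyl on a nitrogen on an aromatic ring in one place, with (methoxycarbonyl)methyl in place of 4-aminophenyl on a nitrogen on an aromatic ring. Going by the values given here, no measured step isolates a change of this kind. Among the compounds with values here, the only hint is that compound 1, which also lacks the 4-aminophenyl, stands at 10000 nM as the weaker of the pair. The estimated 2.0-fold higher number from compound 2 to compound 3 (0.30 log units; within the scatter) is therefore expected to point toward a weaker inhibitor in this assay and to be modest in size. Compound 3 is expected at 8000 nM with an estimated range from 3000 nM to 20000 nM for its value.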

Compound 3, half-maximal inhibitory concentration: 1000 nM
Beside the measured number, compound 3's estimate is 8.0-fold (0.90 log units) above it; the whole stated range lies above it.
By their numbers in this assay, from the lowest: compound 3; then compound 2; then compound 1.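

The step of a 4.0-fold lower number from compound 2 to compound 3 (0.60 log units; beyond the scatter) in this assay shows that the 4-aminophenyl is not needed at this place on the nitrogen on an aromatic ring. Replacing it with (methoxycarbonyl)methyl removes the six-membered aromatic ring and the hydrogen-bond donor of that group, yet gives a stronger inhibitor, so a group with no ring can stand here. Nothing measured here bears on what lies behind this shift.

The compounds shown leave open whether the methyl ester itself matters, as they do not tell how a carboxylic acid or a primary amide would stand on this nitrogen. They also do not tell whether a longer chain ending in the same ester, or a plain alkyl chain, would hold the gain.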